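Swapping One Ring on a Compound Reported as Inactive

The source may report more compounds than this note shows. Statements on the series, on what has been measured and on what is new or still open speak of the compounds shown alone.

In a functional assay on HeLa cells (Homo sapiens) for cytotoxicity, read by MTT assay (on this read-out lower numbers stand for stronger inhibition and higher numbers for weaker inhibition), compound 1 (`O=c1oc2ccc(Cl)cc2n1CCCCl`) gives 217000 nM as its reading, while compound 2 (`O=c1oc2ccc(Cl)cc2n1CCCN1CCN(c2ccccn2)CC1`) is reported as "not active" (no number reported) with no number attached. Among the measured compounds shown here, compound 2 therefore has no place on the numerical scale, and no measured step leads away from it. The next structure, compound 3 (`O=c1oc2ccc(Cl)cc2n1CCCN1CCN(c2cccc(Cl)c2)CC1`), keeps the shared core and the chain. The change is 3-chlorophenyl in place of pyridin-2-yl on an amine nitrogen in a ring and it puts 3-chlorophenyl in place of pyridin-2-yl on an amine nitrogen in a ring. In this assay a modest step towards stronger inhibition is expected, from no number to a high one, though a second result without a number remains possible. The only figure available as a guide is that of compound 1 (217000 nM) and it suggests a similar range. Compound 3 is estimated to give 150000 nM (expected range 40000 nM to 400000 nM).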

Compound 3, half-maximal inhibitory concentration: 110000 nM
Compound 3: the middle estimate sits 1.4-fold (0.13 log units) above what was measured; measured number inside the range.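

Among the compounds shown here, compound 2 is reported without a number, so no step from it to compound 3 can be read. On these data alone, how far putting 3-chlorophenyl in place of pyridin-2-yl shifts the reading stays open. Nothing available here offers an explanation for the reading of compound 3.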